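This account rests on a few compounds, and the source may have more. Where it says the series, first, only, none or still open, it means among the compounds named here.

Measured compounds: compound 1 `O=C(CCCCC#Cc1cccc(Cl)c1Cl)c1ncc(-c2ccccn2)o1`, 5 nM; compound 2 `COC(=O)c1ccc(CCCCCCC(=O)c2ncc(-c3ccccn3)o2)cc1`, 1.5 nM; compound 3 `O=C(CCCCCCc1ccc2ccccc2c1)c1ncc(-c2ccccn2)o1`, 11 nM.

Of these three, compound 2 gives the lowest number in an assay for inhibition of Fatty-acid amide hydrolase 1 (Rattus norvegicus) (on this read-out higher numbers stand for weaker inhibition and lower numbers for stronger inhibition), with both compound 1 and compound 3 standing higher by more than the usual scatter. Compound 4 `O=C(O)c1ccc(CCCCCCC(=O)c2ncc(-c3ccccn3)o2)cc1` is compound 2 with hydrogen in place of methyl on an oxygen next to a carbonyl group. Among the measured compounds shown here, no pair of measured compounds isolates this change, so the expectation rests on the value of compound 2 and on the change alone. The step from compound 2 to compound 4 is expected to be a 5.3-fold higher number from compound 2 to compound 4 (0.73 log units; beyond the scatter), a moderate rise that lies beyond the scatter. Compound 4 is therefore estimated at 8 nM in this assay, within a range from 2 nM to 40 nM.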

Compound 4, inhibition constant: > 600 nM
Compound 4: a limit, no number; the forecaster's own chance of this, stated with the estimate: 3%; middle value at least 75-fold (1.87 log units) from the limit.
By their numbers in this assay, from the lowest: compound 2; then compound 1; then compound 3. At a limit, above all of these: compound 4.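

In this assay compound 4 gives > 600 nM, which is a limit of the assay and not a number. The change from methoxycarbonyl to carboxy gives an at least 400-fold higher number from compound 2 to compound 4 (2.60 log units; beyond the scatter), the first change in one place among these compounds, and its full size remains unknown. The earlier compounds shown here gave no reading of this position, and this step shows that the low number of the methyl ester is not kept by the carboxy compound. The compounds shown do not tell whether an amide or an ethyl ester here would keep that low number, or whether a carboxylic acid on a shorter chain would behave in the same way.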